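Trifluoromethyl to Methoxy: Expected Loss of Growth Inhibition

This account rests on a few compounds, and the source may have more. Where it says the series, first, only, none or still open, it means among the compounds named here.

Compound 1 `Cc1cc(C)c2sc(NC(=O)c3ccc(C(F)(F)F)cc3)nc2c1` — 1.36 ug/mL
Compound 2 `COc1ccc(C(=O)Nc2nc3cc(OC)ccc3s2)cc1` — > 10 ug/mL

Of the compounds shown here, two have been measured in a functional assay on SK-HEP1 cells (Homo sapiens) for antiproliferative activity, read by sulforhodamine B assay; on this read-out lower numbers stand for stronger inhibition of growth and higher numbers for weaker inhibition of growth. For the measured compounds named here, compound 1 gives 1.36 ug/mL, the only actual number among the results. Compound 2 returns in this assay only a limit, > 10 ug/mL, and not a measured number. Thus compound 1 stands as the single compound with a defined value, alongside (the limit of > 10 ug/mL in this assay, at which 1 of the 2 values shown sits).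

Compound 3 `COc1ccc(C(=O)Nc2nc3cc(C)cc(C)c3s2)cc1` is not yet measured. It differs from compound 1 by methoxy in place of trifluoromethyl on an aromatic carbon, so that the rest of the molecule, with the two methyl groups on the shared core, is kept. Going by the values given here, no measured pair shows this exact exchange on an otherwise identical scaffold. Compound 2, however, carries methoxy on the same ring and only reaches the limit of this assay. On that ground the step from compound 1 to compound 3 is expected to run toward weaker inhibition, by a 3.7-fold higher number from compound 1 to compound 3 (0.57 log units; beyond the scatter), beyond the usual scatter. The estimate for compound 3 in this assay is 5 ug/mL, with a range from 2 ug/mL to 12 ug/mL.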

Compound 3, concentration for 50% growth inhibition: > 10 ug/mL
Compound 3: a limit, no number (the forecaster's own chance of this, stated with the estimate: 35%); middle value at least 2.0-fold (0.30 log units) away from the limit.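

For the compounds shown here, with compound 3, methoxy in place of trifluoromethyl on an aromatic carbon, para to a large group, can be read for the first time on an otherwise unchanged molecule: in this assay this single change gives an at least 7.3-fold higher number from compound 1 to compound 3 (0.86 log units; beyond the scatter). The value of compound 3, > 10 ug/mL, is a limit and not a number. The two methyl groups on the shared core therefore do not preserve measurable growth inhibition once methoxy stands at this position, and compound 1 remains the only compound with a defined value: the limit of > 10 ug/mL in this assay, at which 2 of the 3 values shown sit.

The compounds shown leave open how a chlorine, a nitrile or an amine in the place of trifluoromethyl would read in this assay, and so whether measurable inhibition is confined to trifluoromethyl at this position. They also leave open how large the step truly is, and whether trifluoromethyl would give a measurable value on the core of compound 2.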